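The source may report more compounds than this note shows. Statements on the series, on what has been measured and on what is new or still open speak of the compounds shown alone.

The shared core appears in compound 1 `COc1cc(-c2nnc3n2NC(c2ccco2)C(C(=O)c2ccc(F)c(F)c2)S3)cc(OC)c1OC`, compound 2 `COc1cc(-c2nnc3n2NC(c2ccco2)C(C(=O)c2ccco2)S3)cc(OC)c1OC` and compound 3 `COc1cc(-c2nnc3n2NC(c2ccco2)C(C(=O)C2CC2)S3)cc(OC)c1OC`, which differ only in the group on the carbonyl carbon. In a functional assay on A549 cells (Homo sapiens) for cytotoxicity, read by MTT assay, with a stated time of 48 h (a lower number here means a stronger inhibitor, a higher number a weaker inhibitor), compound 1 gives 93700 nM. In this assay compound 2 gives 68700 nM. For compound 3 this assay reports only a limit, > 100000 nM, so compound 3 stands at the edge of what can be read, namely (the limit of > 100000 nM in this assay, at which 1 of the 3 values shown sits). The step of an at least 1.0-fold higher number from compound 1 to compound 3 (0.02 log units; that floor lies within the scatter) and the step of an at least 1.4-fold higher number from compound 2 to compound 3 (0.16 log units; that floor lies within the scatter) both lie within the scatter, so these three compounds cannot be placed in any order. Compound 4 `COc1cc(-c2nnc3n2NC(c2ccco2)C(C(=O)c2cccc(Br)c2)S3)cc(OC)c1OC` is the next member: 3-bromophenyl in place of cyclopropyl on a carbonyl carbon. The measured steps that bear on this change run the other way, from an aryl or furan-2-yl group to cyclopropyl, and neither moved beyond the scatter, so read backwards they point to no step beyond the scatter in this assay, with a lower number slightly more likely than a higher one. Compound 4 is therefore expected to give about 90000 nM in this assay, with a range from 45000 nM to 180000 nM. This corresponds to an expected step of an at least 1.1-fold lower number from compound 3 to compound 4 (0.04 log units; that floor lies within the scatter).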

Compound 4, half-maximal inhibitory concentration: 36900 nM
Compound 4: middle estimate off by 2.4-fold (0.39 log units), on the high side, and the stated range ends above it.
By their numbers in this assay, from the lowest: compounds 4, 2 and 1 (each within the scatter of the next, the first and the last beyond it). At a limit, above all of these: compound 3.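

In this assay, among the compounds shown here, the 3-bromophenyl group gives the first steps on this carbonyl carbon that lie beyond the scatter, with an at least 2.7-fold lower number from compound 3 to compound 4 (0.43 log units; beyond the scatter) and with a 2.5-fold lower number from compound 1 to compound 4 (0.40 log units; beyond the scatter) as well. The 3,4-difluorophenyl group of compound 1 did not separate from cyclopropyl, so a phenyl ring on the carbonyl carbon is not enough in itself, while a 1.9-fold lower number from compound 2 to compound 4 (0.27 log units; within the scatter) leaves the 3-bromophenyl and furan-2-yl groups unordered. Compound 3 is held only as a limit, so its step gives a floor and not a size: the limit of > 100000 nM in this assay, at which 1 of the 4 values shown sits.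

Whether the bromine itself matters stays open, since the compounds shown do not include an unsubstituted phenyl group or chlorine in its place. Also open, going by these compounds, is whether a methoxy group or an amine on that ring would go beyond the scatter from compound 4.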